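The source may hold more compounds than are shown below. What is called first, only, known or untested is meant among the compounds shown, and "the series" means these compounds.

Measured in a physicochemical assay for lipophilicity, read by HPLC, measured as chromatographic lipophilicity, at pH 7.4; on this read-out higher numbers stand for higher lipophilicity and lower numbers for lower lipophilicity:
- compound 1 `CC(=O)N1CCC(C(=O)N2N=CCC2c2ccccc2)CC1`: 2.5
- compound 2 `O=C(C1CCN(C(=O)C(F)(F)F)CC1)N1N=CCC1c1ccccc1`: 4.9

Of these two, compound 2 stands higher, at 4.9. Next comes compound 3 `O=C(C1CCN(c2ccccc2)CC1)N1N=CCC1c1ccccc1`, with phenyl in place of (trifluoromethyl)carbonyl on an amine nitrogen in a ring.

Within the data shown here, only one measured step bears on this change. It is a number 2.40 log units higher from compound 1 to compound 2 (beyond the scatter), a large step beyond the scatter, and it alters the group that compound 3 no longer carries. It shows that this assay can respond strongly to a change in that group. However, it replaces only part of the group, whereas compound 3 loses all of it, so it is a loose guide to size and direction. Among the measured compounds shown here, a moderate rise is expected, with no measured step to confirm it. The expected change is a number 0.60 log units higher from compound 2 to compound 3 (beyond the scatter). For compound 3 the estimated value is 5.5, with an expected range of 4.7 to 6.3.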

Compound 3, distribution coefficient: 6.3
For compound 3 the middle estimate is 0.80 log units below the measured one, and the stated range covers the measured number.
By their numbers in this assay, from the lowest: compound 1; then compound 2; then compound 3.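

In this assay, the amine nitrogen in the ring tolerates more than a change within the carbonyl group: swapping the whole (trifluoromethyl)carbonyl for phenyl gives a number 1.40 log units higher from compound 2 to compound 3 (beyond the scatter) and is still a large step, so the top of the range was not reached with compound 2. Against acetyl, the same replacement gives a number 3.80 log units higher from compound 1 to compound 3 (beyond the scatter) and is the widest step in the series, which places the three groups on this nitrogen in the order acetyl, (trifluoromethyl)carbonyl, phenyl. No supporting data explain why phenyl ends up highest.

Still open, on these data alone, is where a benzyl group, a pyridine ring or a plain alkyl chain on this nitrogen would fall in that order. Also open, as far as these compounds go, is whether a fluorine or a methoxy group on the entering phenyl would shift the number further.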